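The source may report more compounds than this note shows. Statements on the series, on what has been measured and on what is new or still open speak of the compounds shown alone.

Measured compounds:
compound 1 `O=C(O)C1CCN(c2ccccc2F)C1` gives 11000 nM;
compound 2 `O=C(O)C1CCN(c2cccc(C(F)(F)F)c2)C1` gives 11000 nM;
compound 3 `O=C(O)C1CCN(c2ccc(F)c(C(F)(F)F)c2)C1` gives 2500 nM.

In an assay on cells for inhibition of Palmitoleoyl-protein carboxylesterase NOTUM variant C330S (Homo sapiens), read by fluorescence, with a stated time of 40 min (a lower number here means a stronger inhibitor, a higher number a weaker inhibitor), compound 2 stands level with compound 1 at the digits shown, the two together the highest numbers of the three, while compound 3 lies furthest from it. Compound 4 `O=C(O)C1CCN(c2cccc(C(F)(F)F)c2F)C1` is compound 2 with fluoro in place of hydrogen on an aromatic carbon. Among the compounds with values here, the one measured step of the same kind, a fluorine entering at a different aromatic carbon, is a 4.4-fold lower number from compound 2 to compound 3 (0.64 log units; beyond the scatter). Within the data shown here, that single step is the only guide, and it offers no direct evidence for the position taken in compound 4, so only a modest gain, or none beyond the scatter, is expected. For compound 4 the expected step is a 1.6-fold lower number from compound 2 to compound 4 (0.20 log units; within the scatter), giving an estimated value of 7000 nM with a range from 2500 nM to 16000 nM.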

Compound 4, half-maximal inhibitory concentration: 6800 nM
For compound 4 the middle estimate is 1.0-fold (0.01 log units) above the measured one, within the range that was stated.
By their numbers in this assay, from the lowest: compound 3; then compounds 4, 1 and 2 (each within the scatter of the next).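

In this assay, fluoro on the aromatic carbon ortho to a trifluoromethyl group gives a 1.6-fold lower number from compound 2 to compound 4 (0.21 log units; within the scatter), so the step seen earlier at a different aromatic carbon, a 4.4-fold lower number from compound 2 to compound 3 (0.64 log units; beyond the scatter), does not carry over to this position beyond the scatter. Trifluoromethyl in place of hydrogen gives a 1.6-fold lower number from compound 1 to compound 4 (0.21 log units; within the scatter), so adding this group to the core of compound 1 also stays within the scatter. Nothing available bears on why the two fluorine positions read differently. As far as these compounds go, whether chloro, methoxy or an amine on this same aromatic carbon would give a different number remains open.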